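This account rests on a few compounds, and the source may have more. Where it says the series, first, only, none or still open, it means among the compounds named here.

Compound 2 `COc1cc(Cl)cc(-c2nn(-c3cccc(NC(=O)Nc4cccc(C(F)(F)F)c4)c3)cc2-c2ccncc2)c1` is the starting point. In a functional assay on SR cells (Homo sapiens) for inhibition, read by sulforhodamine B assay, with a stated time of 48 h, tested at 100 uM (a lower number here means a stronger effect, a higher number a weaker effect of the compound at the concentration tested), compound 2 gives -30%, the lowest of the two numbers here. Its nearest neighbour, compound 1 `COc1cc(Cl)cc(-c2nn(-c3cccc(NC(=O)Nc4ccc(Cl)c(Cl)c4)c3)cc2-c2ccncc2)c1`, gives -26% in this assay; between them the measured step is a number 4 percentage points lower from compound 1 to compound 2 (within the scatter). Compound 3 `COc1cc(Cl)cc(-c2nn(-c3cccc(NC(=O)c4cccc(C(F)(F)F)c4)c3)cc2-c2ccncc2)c1` differs from compound 2 by 3-(trifluoromethyl)phenyl in place of (3-(trifluoromethyl)phenyl)amino on a carbonyl carbon. Among the compounds with values here, the only measured step concerns a group on the other ring, so it gives no direct guide to this change at the carbonyl carbon. The expected step is therefore a number 8 percentage points higher from compound 2 to compound 3 (within the scatter), not beyond the scatter. Compound 3 is estimated at -22%, with a range from -48% to 4%.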

Compound 3, a percentage reported as activity, at one concentration (the size of the read-out at that concentration, not a potency): 15%
Compound 3: the middle estimate sits 37 percentage points below what was measured, and the stated range ends below it.
By their numbers in this assay, from the lowest: compounds 2 and 1 (each within the scatter of the next); then compound 3.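

Replacing (3-(trifluoromethyl)phenyl)amino on the carbonyl carbon with 3-(trifluoromethyl)phenyl gives a number 45 percentage points higher from compound 2 to compound 3 (beyond the scatter) in this assay, and replacing (3,4-dichlorophenyl)amino with the same group gives a number 41 percentage points higher from compound 1 to compound 3 (beyond the scatter) here as well. Unlike the earlier change to the ring alone, this change, which removes the amino nitrogen and its hydrogen-bond donor, clearly weakens the effect. No measurement here explains the loss.

On these data alone, it remains open whether the nitrogen itself is what counts, since a methylene or an ether oxygen in its place could separate its role from that of the linker's length.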